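Para-bromo for para-propyl in a diaryl urea

This account rests on a few compounds, and the source may have more. Where it says the series, first, only, none or still open, it means among the compounds named here.

Compound 1 `CCCc1ccc(NC(=O)N[C@H](C)c2ccccc2)cc1` – 31%
Compound 2 `CCCc1ccc(NC(=O)N[C@@H](C)c2ccccc2)cc1` – 76%
Compound 3 `C[C@@H](NC(=O)Nc1ccccc1C(F)(F)F)c1ccccc1` – 95%

In an ADME assay on the whole organism with Oryza sativa as the target, tested at 1 uM (on this read-out higher numbers stand for a weaker effect at the one concentration tested and lower numbers for a stronger effect), compound 1 stands lowest of the three, nearest to compound 2 and furthest from compound 3. Going by the values given here, the one counted step, a number 45 percentage points higher from compound 1 to compound 2 (beyond the scatter), is the largest in the set, and the fact that compounds 1 and 2 differ only in the configuration as drawn is all that underlies it. Compound 4 `C[C@@H](NC(=O)Nc1ccc(Br)cc1)c1ccccc1` carries the change bromo in place of propyl on an aromatic carbon at the place para to a large group. Among the compounds with values here, no measured step exchanges one group for another at that place, so nothing bears directly on it. The step of a number 9 percentage points higher from compound 1 to compound 4 (within the scatter) is therefore expected to stay within the scatter. Compound 4 is estimated at 40%, between 15% and 75%.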

Compound 4, a percentage reported as activity, at one concentration (the size of the read-out at that concentration, not a potency): 95%
The estimate for compound 4 lay 55 percentage points below the measured number; measured number outside the range, above it.
By their numbers in this assay, from the lowest: compound 1; then compound 2; then compounds 3 and 4 (each within the scatter of the next).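

Going by these compounds alone, the exchange of propyl for bromo on an aromatic carbon para to a large group is the first exchange of groups at this place, and in this assay it gives a number 64 percentage points higher from compound 1 to compound 4 (beyond the scatter). The place is therefore not indifferent to what it carries: with bromo the stronger effect of compound 1 is gone. Nothing at hand accounts for this step.

From the compounds shown here alone, whether a butyl chain, an ethyl group or a methoxy group at this place would keep the lower number stays open, and so does how the opposite configuration would read with bromo.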